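A few compounds are considered here, and "the series" means these few. Any claim that something is new, unique, unknown or untested is made for them only; others in the source may bear on it.

For the measured compounds named here, compound 1 `NC(=O)c1c(NC(=O)c2ccccc2Cl)sc2c1CCN(C(=S)Nc1cc(C(F)(F)F)cc(C(F)(F)F)c1)C2` is the only compound of the two measured that yields an actual number: in a functional assay on HeLa cells (Homo sapiens) for antiproliferative activity, with a stated time of 24 h (a lower number here means a stronger inhibitor, a higher number a weaker inhibitor), compound 1 gives 48900 nM. Compound 2 `COc1ccccc1C(=O)Nc1sc2c(c1C(N)=O)CCN(C(=S)Nc1ccccc1Cl)C2` reached only a limit; in this assay compound 2 gives > 50000 nM, which is a limit of the assay rather than a number. Compound 3 `NC(=O)c1c(NC(=O)c2ccccc2F)sc2c1CCN(C(=S)Nc1cc(C(F)(F)F)cc(C(F)(F)F)c1)C2` differs from compound 1 by fluoro in place of chloro on an aromatic carbon. Going by the values given here, no measured pair shows this change, so the step is expected to stay within the scatter: a 1.0-fold higher number from compound 1 to compound 3 (0.01 log units; within the scatter). Compound 3 is thus estimated at 50000 nM, between 20000 nM and 120000 nM.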

Compound 3, half-maximal inhibitory concentration: 28000 nM
Beside the measured number, compound 3's estimate is 1.8-fold (0.25 log units) above it, and the stated range covers the measured number.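

With this step the 2-chlorophenyl ring gets its first reading: in this assay, fluoro in place of chloro gives a 1.7-fold lower number from compound 1 to compound 3 (0.24 log units; within the scatter). This swap of one halogen for another, ortho to a large group, therefore does not separate the two compounds. Compound 2 gives only a limit of the assay, not a number, and that limit sits close above the measured numbers: the limit of > 50000 nM in this assay, at which 1 of the 3 values shown sits.

On these data alone, whether a different kind of group at this place, such as an amine or a carboxylic acid, would move the number stays open. So does whether any such group could bring the number well away from that limit.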